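A few compounds are considered here, and "the series" means these few. Any claim that something is new, unique, unknown or untested is made for them only; others in the source may bear on it.

Measured in an ADME assay on RAW264.7 cells (Mus musculus) for cytotoxicity, read by MTT assay, with a stated time of 24 h, in the presence of a further agent that is not named here; on this read-out lower numbers stand for stronger inhibition and higher numbers for weaker inhibition:
- compound 1 `Cc1noc(CC2OC(=O)c3ccccc32)n1`: > 40000 nM
- compound 2 `O=C1OC(Cc2nc(Cc3ccccc3)no2)c2ccccc21`: > 40000 nM
- compound 3 `CCCOc1ccc(C(O)C2OC(=O)c3c(OC)cc(OC)cc32)cc1`: > 40000 nM

Each of these values is a limit of the assay and not a number, as the series summary shows: the limit of > 40000 nM in this assay, at which 3 of the 3 values shown sit.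

Compound 3 stands at > 40000 nM, which is a limit. Compound 4 `COCCOc1ccc(C(O)C2OC(=O)c3c(OC)cc(OC)cc32)cc1` changes propoxy to 2-methoxyethoxy: methoxy in place of methyl on a saturated chain carbon, two bonds along the chain from an oxygen on an aromatic ring. Among the compounds with values here, the only measured step, a step that the two limits leave unreadable from compound 1 to compound 2, is a different change and gives no size to carry over. With compound 3 at > 40000 nM, still a limit, no shift beyond the scatter is expected in this assay. The expected step is a step that the limit leaves unreadable from compound 3 to compound 4. Compound 4 is expected at 50000 nM, with an estimated range of 25000 nM to 100000 nM.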

Compound 4, half-maximal inhibitory concentration: > 40000 nM
Compound 4 ended at the assay's limit; the forecaster's own chance of this, stated with the estimate: 85%; the middle value does not contradict the limit.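

In this assay no step can be read from compound 3 to compound 4, as both values are limits of the assay: the limit of > 40000 nM in this assay, at which 4 of the 4 values shown sit.

The compounds shown leave open where any of their actual half-maximal inhibitory concentrations lies and whether the change from propoxy to 2-methoxyethoxy alters it.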